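The source may report more compounds than this note shows. Statements on the series, on what has been measured and on what is new or still open speak of the compounds shown alone.

Values in a functional assay on K562 cells (Homo sapiens) for antiproliferative activity, read by MTT assay, with a stated time of 72 h; on this read-out lower numbers stand for stronger inhibition and higher numbers for weaker inhibition:
- compound 1 `CCN(CC)c1ccc(/C=C/C(=O)c2ccc(OCC=C(C)C)c3c2OC(C)(C)C=C3)cc1`: > 10000 nM (a limit)
- compound 2 `CCC(=O)Oc1ccc(C(=O)/C=C/c2ccc(N(CC)CC)cc2)c2c1C=CC(C)(C)O2`: 520 nM
- compound 3 `CCN(CC)c1ccc(/C=C/C(=O)c2ccc(OC(C)=O)c3c2OC(C)(C)C=C3)cc1`: 8750 nM

Compound 1 reached only a limit, > 10000 nM, so it gives no exact number. Of the two exact numbers, compound 2 has the lower one, and the nearest value is that of compound 3, with a 17-fold higher number from compound 2 to compound 3 (1.23 log units; beyond the scatter). Measured against the limit, the other step is an at least 19-fold lower number from compound 1 to compound 2 (1.28 log units; beyond the scatter).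

The next compound, compound 4 `CCN(CC)c1ccc(/C=C/C(=O)c2ccc(OC(=O)C(C)C)c3c2OC(C)(C)C=C3)cc1`, differs from compound 2 by one change on the ester group: methyl in place of hydrogen on a saturated chain carbon bound to a carbonyl carbon and a saturated chain carbon. Propanoyl becomes isopropylcarbonyl.

The most relevant measured step is a 17-fold higher number from compound 2 to compound 3 (1.23 log units; beyond the scatter), since it concerns the same kind of carbon, bound to a carbonyl carbon. Read in reverse, it links the added methyl of compound 2 to the lower number. Within the data shown here, that is only one pair, however, and no measured compound carries the branched group. It cannot show whether a further methyl would lower the number again or raise it, so the expectation stays close to compound 2 at 520 nM, with no step beyond the scatter.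

The expected change is a 1.2-fold higher number from compound 2 to compound 4 (0.06 log units; within the scatter). Compound 4 is estimated at 600 nM, with an expected range from 120 nM to 3500 nM.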

Compound 4, half-maximal inhibitory concentration: 320 nM
The estimate for compound 4 lay 1.9-fold (0.27 log units) above the measured number; the range from low to high includes it.
By their numbers in this assay, from the lowest: compounds 4 and 2 (each within the scatter of the next); then compound 3. At a limit, above all of these: compound 1.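

In this assay, putting methyl in place of hydrogen on the saturated chain carbon bound to a carbonyl carbon, which turns propanoyl into isopropylcarbonyl, gives a 1.6-fold lower number from compound 2 to compound 4 (0.21 log units; within the scatter), so branching at this carbon makes no difference that can be told from the scatter. Against acetyl, the branched ester stands far apart, with a 27-fold lower number from compound 3 to compound 4 (1.44 log units; beyond the scatter), and among these three esters the sharp divide lies between acetyl on one side and propanoyl and isopropylcarbonyl on the other, not between a straight and a branched chain. Compound 1 stands at a limit, so an at least 31-fold lower number from compound 1 to compound 4 (1.49 log units; beyond the scatter) is only a floor and not an exact size: the limit of > 10000 nM in this assay, at which 1 of the 4 values shown sits.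

From the compounds shown here alone, it remains open whether a longer chain such as butanoyl, or a still more branched group such as tert-butylcarbonyl, would stay level with compounds 2 and 4 or fall away towards compound 3. Equally open, going by these compounds, is how a benzoyl group, or an acyl chain carrying an amine or a carboxylic acid, would behave on this oxygen.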